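Losing the Hydroxy Group on the Aryl Arm

The compounds below may be only part of what the source reports. "The series", "measured", "known", "first", "only" and "open" are said of these compounds alone.

Compound 1 `COc1cc(-n2cnc3ccc(-c4cc(F)ccc4F)cc32)cc(OC)c1OC`, compound 2 `COc1cc(-n2cnc3ccc(-c4ccccc4)cc32)cc(OC)c1OC` and compound 3 `COc1cc(-n2cnc3ccc(-c4cccc(O)c4)cc32)cc(OC)c1OC` share one core and differ only in the aryl arm. In a functional assay on MCF7 cells (Homo sapiens) for antiproliferative activity, read by MTT assay, with a stated time of 72 h (on this read-out higher numbers stand for weaker inhibition and lower numbers for stronger inhibition), compound 1 gives 6420 nM, compound 2 gives 2290 nM and compound 3 gives 350 nM, the lowest of the three and therefore the strongest inhibitor shown. The steps are a 2.8-fold lower number from compound 1 to compound 2 (0.45 log units; beyond the scatter), an 18-fold lower number from compound 1 to compound 3 (1.26 log units; beyond the scatter) and a 6.5-fold lower number from compound 2 to compound 3 (0.82 log units; beyond the scatter).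

Compound 4 `COc1ccc(-c2ccc3ncn(-c4cc(OC)c(OC)c(OC)c4)c3c2)cc1` differs from compound 3 as follows: 4-methoxyphenyl in place of 3-hydroxyphenyl on an aromatic carbon. The step that bears most on this is a 6.5-fold lower number from compound 2 to compound 3 (0.82 log units; beyond the scatter), since the hydrogen-bond donor that produced that gain is now gone. For compound 4 a higher number is expected, with a step of a 4.3-fold higher number from compound 3 to compound 4 (0.63 log units; beyond the scatter). Compound 4 is estimated at 1500 nM, in a range from 500 nM to 4500 nM.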

Compound 4, half-maximal inhibitory concentration: 210 nM
Compound 4: middle estimate off by 7.1-fold (0.85 log units), on the high side; measured number outside the range, below it.
By their numbers in this assay, from the lowest: compounds 4 and 3 (each within the scatter of the next); then compound 2; then compound 1.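

The hydrogen-bond donor on the aryl arm proves not to be needed for this level of activity: 4-methoxyphenyl in place of 3-hydroxyphenyl gives a 1.7-fold lower number from compound 3 to compound 4 (0.22 log units; within the scatter) and so leaves the number unchanged in practice. Against the other arms, the methoxy group gives an 11-fold lower number from compound 2 to compound 4 (1.04 log units; beyond the scatter) and the full swap gives a 31-fold lower number from compound 1 to compound 4 (1.49 log units; beyond the scatter), so both oxygen-bearing arms sit well ahead of the plain phenyl and 2,5-difluorophenyl arms. No measurement available here explains this.

As far as these compounds go, the group and its place change together from compound 3 to compound 4, so their separate effects stay open. From the compounds shown here alone, whether an amine or a longer ethoxy chain on the arm would do as well also stays open.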